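The source may hold more compounds than are shown below. What is called first, only, known or untested is meant among the compounds shown, and "the series" means these compounds.

Measured compounds:
compound 1 `O=C(Nc1cccc(Oc2nccc(C(F)(F)F)c2Cl)c1)C1CCCN(C(=O)c2cc(C(F)(F)F)cc(C(F)(F)F)c2)C1`, 0%
compound 2 `COC(=O)c1cccc(C(=O)N2CCCC(C(=O)Nc3ccc(Cl)cc3)C2)c1`, 0%
compound 3 `Cc1nc(-c2cccc(C(=O)N3CCCC(C(=O)Nc4ccc(Cl)cc4)C3)c2)no1`, 0%

All three were tested in an ADME assay on PC-3 cells (Homo sapiens) for cytotoxicity, read by WST assay, tested at 100 uM; a lower number here means less inhibition, a higher number more inhibition at the concentration tested (going by the name of the read-out). In this assay compound 1 stands level with compound 2 and compound 3 at the digits shown, and none of the three shows any inhibition. Within the data shown here, the only single-point step among the measured compounds, no change at the digits printed from compound 2 to compound 3 (within the scatter), lies within the scatter.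

Compound 4 `CC(C)(C)OC(=O)c1cccc(NC(=O)C2CCCN(C(=O)c3cc(C(F)(F)F)cc(C(F)(F)F)c3)C2)c1` is not yet measured. It differs from compound 1 in one place: tert-butoxycarbonyl in place of (3-chloro-4-(trifluoromethyl)pyridin-2-yl)oxy on an aromatic carbon. Among the measured compounds shown here, no measured step touches this particular exchange, so the step from compound 1 to compound 4 in this assay cannot be estimated from a directly comparable pair. Since every measured compound, including compound 1 at 0%, gives no inhibition, compound 4 is expected to behave the same, with a step of no change at the digits printed from compound 1 to compound 4 (within the scatter), that is, no change beyond the scatter. The estimate for compound 4 is 0%, ranging from -5% to 12%.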

Compound 4, a percentage reported as inhibition, at one concentration (the size of the read-out at that concentration, not a potency): 0%
For compound 4 middle estimate and measured number coincide at the digits printed, and the stated range covers the measured number.
By their numbers in this assay, from the lowest: compounds 1, 2, 3 and 4 (each within the scatter of the next).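

In this assay, putting tert-butoxycarbonyl in place of (3-chloro-4-(trifluoromethyl)pyridin-2-yl)oxy gives no change at the digits printed from compound 1 to compound 4 (within the scatter). This extends the flat picture to a second place: on this six-membered aromatic ring of carbon only, a group with no ring and one with a six-membered aromatic ring read alike. No available evidence bears on this result. As far as these compounds go, whether an amine or a carboxylic acid at this position would read the same remains open. So does whether any change here can produce a measurable reading in this cell test.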